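Capping one acid group on a weak inhibitor

The source may hold more compounds than are shown below. What is called first, only, known or untested is meant among the compounds shown, and "the series" means these compounds.

Compound 1 `CC(=O)Oc1ccc(C(=O)C2=C(O)[C@]3(CC=C(C)C)C[C@@H](C/C=C(\C)CCC=C(C)C)[C@](C)(CCC=C(C)C)[C@](CC=C(C)C)(C2=O)C3=O)cc1OC(C)=O` and compound 2 `CC(C)=CCC/C(C)=C/C[C@@H]1C[C@]2(CC=C(C)C)C(=O)[C@@](CC=C(C)C)(C(=O)C(C(=O)c3ccc(OCC(=O)O)c(OCC(=O)O)c3)=C2O)[C@@]1(C)CCC=C(C)C` share a core but carry different side groups. In a functional assay on A549 cells (Homo sapiens) for inhibition, read by MTT assay, with a stated time of 72 h (a higher number here means a weaker inhibitor, a lower number a stronger inhibitor), compound 1 gives 16600 nM. Compound 2 gives > 20000 nM, which is a limit of the assay and not a number. Compound 2 therefore has no exact position on the scale.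

Compound 3 `COC(=O)COc1ccc(C(=O)C2=C(O)[C@]3(CC=C(C)C)C[C@@H](C/C=C(\C)CCC=C(C)C)[C@](C)(CCC=C(C)C)[C@](CC=C(C)C)(C2=O)C3=O)cc1OCC(=O)O` differs from compound 2 by a single change, methyl in place of hydrogen on an oxygen next to a carbonyl group. One carboxymethyl thus becomes (methoxycarbonyl)methyl, while the other carboxymethyl stays.

For the measured compounds named here, no measured pair of compounds shows what this change does in this assay, so any forecast is uncertain. The nearest real number comes from compound 1 at 16600 nM, which has no carboxymethyl group, so a modest move toward stronger inhibition is expected. The estimated size of that move is an at least 1.2-fold lower number from compound 2 to compound 3 (0.09 log units; that floor lies within the scatter). It may not clear the scatter, and another limit would be no surprise. For compound 3 the estimated value is 16000 nM, with an expected range of 8000 nM to 30000 nM.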

Compound 3, half-maximal inhibitory concentration: > 20000 nM
Compound 3 ended at the assay's limit; the forecaster's own chance of this, stated with the estimate: 40%; middle value at least 1.2-fold (0.09 log units) from the limit.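

In this assay compound 3 gives > 20000 nM as a limit of the assay and not a number. The step between compound 2 and compound 3 therefore cannot be read, because both compounds sit at the same limit: the limit of > 20000 nM in this assay, at which 2 of the 3 values shown sit. The compounds shown leave open whether changing carboxymethyl to (methoxycarbonyl)methyl alters inhibition at all.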